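The compounds below may be only part of what the source reports. "The series", "measured", "known", "first", "only" and "open" are said of these compounds alone.

Of the compounds shown here, two of a shared core have been measured in a functional assay on DU-145 cells (Homo sapiens) for antiproliferative activity, read by MTT assay, with a stated time of 24 h; on this read-out higher numbers stand for weaker inhibition and lower numbers for stronger inhibition. Compound 1, `COc1ccc(-c2cc(C(=O)/C=C/c3ccc(Cl)cc3)nc3cc(-c4ccccc4)nn23)cc1OC`, gives 22400 nM in this assay. Compound 2, `COc1ccc(-c2cc(C(=O)/C=C/c3ccc(C)cc3)nc3cc(-c4ccccc4)nn23)cc1OC`, gives 19500 nM in this assay. Within the data shown here, the one step between them, a 1.1-fold lower number from compound 1 to compound 2 (0.06 log units; within the scatter), changes only the group on the far aromatic ring, and on these two numbers compound 2 and compound 1 sit within the scatter of each other, so neither can be called the stronger.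

Compound 3, `COc1cc(-c2cc(C(=O)/C=C/c3ccc(C)cc3)nc3cc(-c4ccccc4)nn23)cc(OC)c1OC`, is not yet measured. It differs from compound 2 by methoxy in place of hydrogen on an aromatic carbon, in other words a methoxy in place of hydrogen on an aromatic carbon, ortho to a methoxy group and meta to a methoxy group, so that the 3,4-dimethoxyphenyl becomes a 3,4,5-trimethoxyphenyl. Among the measured compounds shown here, no measured step touches this ring, and the only step on record was within the scatter. Without a guide, the expectation for compound 3 is a number close to that of compound 2, with a step of about a 1.3-fold lower number from compound 2 to compound 3 (0.11 log units; within the scatter) and no clear direction. Compound 3 is therefore estimated at 15000 nM in this assay, most likely between 5000 nM and 45000 nM.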

Compound 3, half-maximal inhibitory concentration: 21900 nM
Compound 3: middle estimate off by 1.5-fold (0.16 log units), on the low side; low and high end bracket the measured number.
By their numbers in this assay, from the lowest: compounds 2, 3 and 1 (each within the scatter of the next).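

Adding one methoxy in place of hydrogen, ortho to a methoxy group and meta to a methoxy group, turns the 3,4-dimethoxyphenyl of compound 2 into the 3,4,5-trimethoxyphenyl of compound 3, and in this assay this gives a 1.1-fold higher number from compound 2 to compound 3 (0.05 log units; within the scatter) and so gives this ring its first measured step, one that does not separate the two compounds. There are now two single changes on record, one on the far aromatic ring and one on this ring, and both lie within the usual scatter, so neither place has yet shown a change that can be told apart from repeat-measurement noise. Nothing measured here speaks to the reason for this result.

The compounds shown leave open whether a different group at this same place, such as a hydroxyl, an amine or a longer chain like ethoxy, would give a step beyond the scatter. They also leave open whether the same added methoxy would read alike with chloro rather than methyl on the far ring, as in the core of compound 1.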